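The source may hold more compounds than are shown below. What is called first, only, known or untested is meant among the compounds shown, and "the series" means these compounds.

Working notes on the series, read in a physicochemical assay for solubility, at pH 7; on this read-out higher numbers stand for higher solubility and lower numbers for lower solubility. Compound 1 `CC(C)(C)C(=O)N1Cc2c(NC(=O)c3ccc(F)cc3)n[nH]c2C1(C)C` gives 235000 nM. Compound 2 `CN(C)CC(=O)Nc1n[nH]c2c1CN(C(=O)C(C)(C)C)C2(C)C` gives > 225000 nM, which is a limit and not a number. Going by the values given here, the one measured step that bears on the next change is a step that the limit leaves unreadable from compound 1 to compound 2, with (dimethylamino)methyl in place of 4-fluorophenyl on a carbonyl carbon, and its size cannot be read. Compound 3 `CC(C)(C)C(=O)N1Cc2c(NC(=O)c3ccncc3)n[nH]c2C1(C)C` carries pyridin-4-yl in place of (dimethylamino)methyl on a carbonyl carbon. Among the compounds with values here, that restores a six-membered aromatic ring at the place where compound 1, at 235000 nM, has one, so the only number available is the one from compound 1. The expected step is a number no higher from compound 2 to compound 3 (the limit leaves the size open), and no size beyond the scatter is expected. Compound 3 is expected at 225000 nM, with an estimated range of 120000 nM to 260000 nM.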

Compound 3, solubility: 205000 nM
For compound 3 the middle estimate is 1.1-fold (0.04 log units) above the measured one; low and high end bracket the measured number.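

In this assay, going by these compounds alone, pyridin-4-yl in place of 4-fluorophenyl on a carbonyl carbon gives a 1.1-fold lower number from compound 1 to compound 3 (0.06 log units; within the scatter), so this exchange of one six-membered aromatic ring for another is the first readable step at this position, and it stays inside the scatter. The comparison with the open chain gives only an at least 1.0-fold lower number from compound 2 to compound 3 (0.04 log units; that floor lies within the scatter), a floor and not a measured size. Compound 2 carries a limit and not a number, so the step from compound 1 to compound 2 cannot be read: the limit of > 225000 nM in this assay, at which 1 of the 3 values shown sits.

Going by these compounds, whether a carboxylic acid or a longer chain ending in an amine on this carbonyl carbon would give a step beyond the scatter stays open. Also open, on these data alone, is how far the true number for compound 2 lies from those of the two aromatic compounds.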